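The compounds below may be only part of what the source reports. "The series", "measured", "known", "first", "only" and "open" are said of these compounds alone.

Three compounds sharing one core differ only in the group attached to the carbonyl carbon. Compound 1 `CCc1ccc(C(=O)N[C@@H]2[C@@H](O)[C@H](n3cnc4c(NC5CCCC5)ncnc43)O[C@@H]2C)cc1` carries a 4-ethylphenyl there, and in an assay on isolated protein for binding affinity to adenosine receptor A1 (Rattus norvegicus), in the absence of a further agent (a higher number here means a weaker inhibitor, a lower number a stronger inhibitor), compound 1 gives 240 nM. Compound 2 `C[C@H]1O[C@@H](n2cnc3c(NC4CCCC4)ncnc32)[C@H](O)[C@H]1NC(=O)CCCc1cccs1` carries a 3-(thiophen-2-yl)propyl, and in this assay compound 2 gives 55 nM. Compound 3 `C[C@H]1O[C@@H](n2cnc3c(NC4CCCC4)ncnc32)[C@H](O)[C@H]1NC(=O)CCCOc1ccccc1` carries a 3-phenoxypropyl, and in this assay compound 3 gives 473 nM, the highest of the three numbers; its gap to compound 1 lies within the scatter, while its gap to compound 2 lies beyond it. The measured steps are a 4.4-fold lower number from compound 1 to compound 2 (0.64 log units; beyond the scatter), a 2.0-fold higher number from compound 1 to compound 3 (0.29 log units; within the scatter) and an 8.6-fold higher number from compound 2 to compound 3 (0.93 log units; beyond the scatter).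

Compound 4 `C[C@H]1O[C@@H](n2cnc3c(NC4CCCC4)ncnc32)[C@H](O)[C@H]1NC(=O)C1(c2ccccc2)CCCC1` differs from compound 3 in one place: 1-phenylcyclopentyl in place of 3-phenoxypropyl on a carbonyl carbon. All three measured steps change this same position, so all bear on the new one, and they span only a modest range, the largest being an 8.6-fold higher number from compound 2 to compound 3 (0.93 log units; beyond the scatter). Among the measured compounds shown here, no measured compound carries a group of this shape, a saturated ring joined to the aromatic ring, on the carbonyl carbon, so the direction is uncertain. A small move is expected, tending toward the lower numbers of compound 1 and compound 2 rather than past them. The expected step is a 2.4-fold lower number from compound 3 to compound 4 (0.37 log units; beyond the scatter). Compound 4 is therefore estimated at 200 nM in this assay, with a range from 60 nM to 700 nM.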

Compound 4, inhibition constant: 138 nM
The estimate for compound 4 lay 1.4-fold (0.16 log units) above the measured number; the range from low to high includes it.
By their numbers in this assay, from the lowest: compound 2; then compounds 4, 1 and 3 (each within the scatter of the next, the first and the last beyond it).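

Among the compounds shown here, the 1-phenylcyclopentyl group is the first group here with a saturated ring joined to the aromatic ring on the carbonyl carbon, and in this assay replacing 3-phenoxypropyl with it gives a 3.4-fold lower number from compound 3 to compound 4 (0.53 log units; beyond the scatter), so this compact ring group can be told apart from the phenoxy chain. It does not match the thiophene chain, however: the change from 3-(thiophen-2-yl)propyl gives a 2.5-fold higher number from compound 2 to compound 4 (0.40 log units; beyond the scatter), and compound 2 keeps the lowest number of the four. The comparison with 4-ethylphenyl gives a 1.7-fold lower number from compound 1 to compound 4 (0.24 log units; within the scatter), so these two quite different groups cannot be separated, even though compound 1 also cannot be separated from compound 3, which sits clearly apart from compound 4.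

The data offer no evidence on why these groups differ. Going by these compounds, it remains open whether a smaller ring in the same arrangement, such as 1-phenylcyclopropyl, or an amine or a carboxylic acid on the phenyl ring of 1-phenylcyclopentyl, would shift the number in either direction.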